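Methoxy added to the central ring of compound 2

The compounds below may be only part of what the source reports. "The series", "measured", "known", "first", "only" and "open" are said of these compounds alone.

Measured so far in an assay on isolated protein for inhibition of tyrosine-protein kinase receptor UFO (Homo sapiens), read by LC-MS; a higher number here means a weaker inhibitor, a lower number a stronger inhibitor:
- compound 1 `COc1ccccc1-c1ccc(-c2nnc(N(C)Cc3ccc4nccn4c3)o2)cc1`: 1580 nM
- compound 2 `Cc1nn(C)c(C)c1-c1ccc(-c2nnc(N(C)Cc3ccc4nccn4c3)o2)cc1`: 1260 nM

Within the data shown here, compound 2 holds the lowest of the two numbers measured, but its only neighbour, compound 1, lies within the scatter of it: a 1.3-fold lower number from compound 1 to compound 2 (0.10 log units; within the scatter). On these two numbers compound 2 and compound 1 are not told apart.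

Compound 3 `COc1cc(-c2c(C)nn(C)c2C)ccc1-c1nnc(N(C)Cc2ccc3nccn3c2)o1` keeps the core of compound 2 and differs in one place: methoxy in place of hydrogen on an aromatic carbon. The new group sits on the six-membered aromatic ring of carbon only, ortho to a large group and meta to the 1,3,5-trimethyl-1H-pyrazol-4-yl group.

Among the measured compounds shown here, no measured step bears on this change. For the measured compounds named here, the one step available, from compound 1 to compound 2, exchanges the outer aryl group and stays within the scatter, so it gives no lead on a methoxy entering the central ring. With nothing to point either way, the expectation for compound 3 in this assay is a step of a 1.0-fold higher number from compound 2 to compound 3 (0.01 log units; within the scatter), which is no step beyond the scatter.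

Compound 3 is therefore estimated at 1300 nM, with a wide range from 400 nM to 4000 nM that reflects the absence of any comparable change among the measured compounds.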

Compound 3, half-maximal inhibitory concentration: 794 nM
For compound 3 the middle estimate is 1.6-fold (0.21 log units) above the measured one, and the stated range covers the measured number.
By their numbers in this assay, from the lowest: compounds 3, 2 and 1 (each within the scatter of the next).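

This position on the six-membered aromatic ring of carbon only accepts methoxy in place of hydrogen with a 1.6-fold lower number from compound 2 to compound 3 (0.20 log units; within the scatter) in this assay, so compound 2 and compound 3 are not told apart. The earlier compounds shown here varied only the outer aryl group; this pair adds that the ring bearing it can also take a substituent ortho to a large group, with the number staying within the scatter of the parent. Nothing measured on these compounds accounts for the step or says what the methoxy does here.

As far as these compounds go, it remains open whether this tolerance is particular to methoxy or extends to other groups at this place, such as fluorine, hydroxyl, a dimethylamino group or a longer alkoxy chain, since a single substituent at a single place on this ring gives no trend. Also open, from the compounds shown here alone, is whether the same methoxy gives a similar step when the 2-methoxyphenyl group of compound 1 stands in place of the 1,3,5-trimethyl-1H-pyrazol-4-yl group.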